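Unsaturated Acid Chain and Mouse Clearance

The source may hold more compounds than are shown below. What is called first, only, known or untested is meant among the compounds shown, and "the series" means these compounds.

Compound 1 `CN(Cc1ccccc1OCCCCC(C)(C)C(=O)O)C(=O)c1ccc(-c2ccco2)cc1` stands second highest of the three numbers in an ADME assay on the whole organism (strain CD-1) for pharmacokinetics, with Mus musculus as the target, at a dose of 3 mg/kg by the intravenous route (a lower number here means slower removal, a higher number faster removal of the compound), at 1.3 mL/min/kg. Compound 2 `C[C@H](CCCOc1ccccc1CN(C)C(=O)c1ccc(-c2ccco2)cc1)CC(=O)O` gives 0.3 mL/min/kg in this assay, and compound 3 `C/C(=C\CCCOc1ccccc1CN(C)C(=O)c1ccc(-c2ccco2)cc1)C(=O)O` gives 4 mL/min/kg. Across the measured steps, a 4.3-fold lower number from compound 1 to compound 2 (0.64 log units; beyond the scatter), while a 3.1-fold higher number from compound 1 to compound 3 (0.49 log units; beyond the scatter). Compound 4 `C/C(=C\C(=O)O)CCCOc1ccccc1CN(C)C(=O)c1ccc(-c2ccco2)cc1` differs from compound 1 by 2-carboxy-1-methylethenyl in place of 2-carboxy-2-methylpropyl on a saturated chain carbon, three bonds along the chain from an oxygen on an aromatic ring. The step to compound 3 bears most on this change, since compound 3 and compound 4 both bring a second double bond outside aromatic rings into the chain carrying the acid, and because a 3.1-fold higher number from compound 1 to compound 3 (0.49 log units; beyond the scatter) a modest rise is expected here too. Compound 4 is therefore estimated at 3 mL/min/kg, with a range of 1 mL/min/kg to 8 mL/min/kg, meaning an expected 2.3-fold higher number from compound 1 to compound 4 (0.36 log units; beyond the scatter).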

Compound 4, clearance: 11 mL/min/kg
Beside the measured number, compound 4's estimate is 3.7-fold (0.56 log units) below it; the whole stated range lies below it.
By their numbers in this assay, from the lowest: compound 2; then compound 1; then compound 3; then compound 4.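

In this assay the two unsaturated chains do not read alike: there is a 2.8-fold higher number from compound 3 to compound 4 (0.44 log units; beyond the scatter), so the placing of the double bond and the methyl counts at this position, not only the presence of a second double bond. The same change gives an 8.5-fold higher number from compound 1 to compound 4 (0.93 log units; beyond the scatter), and against the 1-(carboxymethyl)ethyl chain, which has the same carbon skeleton without that double bond, there is a 37-fold higher number from compound 2 to compound 4 (1.56 log units; beyond the scatter), the largest step in this set. No measurement shown explains these differences.

The compounds shown leave open how the other double-bond geometry of 2-carboxy-1-methylethenyl would read. They also leave open whether a longer chain or a tetrazole in place of the carboxylic acid would follow the same order.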